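The source may report more compounds than this note shows. Statements on the series, on what has been measured and on what is new or still open speak of the compounds shown alone.

Measured in an ADME assay on microsomes from liver (Homo sapiens) for metabolic stability, using NADPH, with a stated time of 10 min; on this read-out lower numbers stand for a less stable compound and higher numbers for a more stable compound:
Compound 1 `NC(=O)NCCCCN(C[C@H]1Cc2ncccc2CN1)[C@H]1CCCc2cccnc21`: 91%
Compound 2 `CCN(CC)CCCCN(C[C@H]1Cc2ncccc2CN1)[C@H]1CCCc2cccnc21`: 80%

For the measured compounds named here, of these two, compound 2 stands lower at 80%, the lowest number so far. Compound 3 `CN(CCCCN(C[C@H]1Cc2ncccc2CN1)[C@H]1CCCc2cccnc21)C1CCC(F)(F)CC1` has not yet been measured. It differs from compound 2 in one place: a group of 10 heavy atoms (7 carbon, 1 nitrogen, 2 fluorine; one six-membered non-aromatic ring of carbon only) in place of a group of 5 heavy atoms (4 carbon, 1 nitrogen; no ring), on a saturated chain carbon, four bonds along the chain from an amine nitrogen. Going by the values given here, only one measured step bears on this change, since it falls at the same place on the chain: a number 11 percentage points lower from compound 1 to compound 2 (beyond the scatter). That step was modest, though beyond the scatter. Neither measured compound has a group of this size at that place, so the evidence is thin. A further modest downward step is expected in this assay, and the estimate is a number 12 percentage points lower from compound 2 to compound 3 (beyond the scatter). For compound 3 the estimated value is 68%, with an expected range from 45% to 88%.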

Compound 3, percent of the compound remaining: 61%
Estimate against measurement, compound 3: 7 percentage points above; measured number inside the range.
By their numbers in this assay, from the lowest: compound 3; then compound 2; then compound 1.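

In this assay, the group with the six-membered non-aromatic ring and two fluorine atoms, on a saturated chain carbon, four bonds along the chain from an amine nitrogen, takes the read-out well below the earlier pair (a number 19 percentage points lower from compound 2 to compound 3 (beyond the scatter); a number 30 percentage points lower from compound 1 to compound 3 (beyond the scatter)). The three groups at this place now give three separate levels, with the ureido compound highest and compound 3 lowest, so the read-out at this place follows the group and can fall further than the first pair showed. Nothing given here accounts for these drops.

The compounds shown leave open whether the fall goes with the ring or with the fluorine atoms, which a plain cyclohexyl group or a morpholine at this place could separate. They also leave open whether an acetamide would stay as high as the ureido group.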